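A few compounds are considered here, and "the series" means these few. Any claim that something is new, unique, unknown or untested is made for them only; others in the source may bear on it.

Compound 1 `COc1cc(N2C(N)=C(C#N)C(/C=C/c3ccccc3)C3=C2CC(C)(C)CC3=O)cc(OC)c1OC` was tested in a functional assay on Ehrlich cells (Mus musculus) for cytotoxicity (on this read-out higher numbers stand for weaker inhibition and lower numbers for stronger inhibition), and there compound 1 gives "not active" (no number reported), so no single number stands for it; one further entry, compound 2 `COc1cc(N2C(N)=C(C#N)C(c3ccccc3Cl)C3=C2CC(C)(C)CC3=O)cc(OC)c1OC`, likewise gives "not active" (no number reported) without a number. Only compound 3 `COc1cc(N2C(N)=C(C#N)C(c3ccc(C)o3)C3=C2CC(C)(C)CC3=O)cc(OC)c1OC` carries a number: in this assay compound 3 gives 216000 nM, a weak result. Compound 4 `COc1cc(N2C(N)=C(C#N)C(c3ccc(O)cc3)C3=C2CC(C)(C)CC3=O)cc(OC)c1OC` has not yet been measured. It differs from compound 1 by 4-hydroxyphenyl in place of 2-phenylethenyl on a saturated ring carbon. With no numbered step between measured compounds, no large change is expected from this swap; compound 4 is expected to stay weak in this assay, and a report of no activity rather than a number is quite possible. The estimate for compound 4 is 250000 nM, with a range from 80000 nM to 800000 nM.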

Compound 4, half-maximal inhibitory concentration: 75800 nM
Compound 4: the middle estimate sits 3.3-fold (0.52 log units) above what was measured; measured number below the stated range.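

The group on this saturated ring carbon does shift the result in this assay: 4-hydroxyphenyl in place of 5-methylfuran-2-yl gives a 2.8-fold lower number from compound 3 to compound 4 (0.45 log units; beyond the scatter). Compound 4 also yields a number where compound 1, with 2-phenylethenyl on the same carbon, is reported as not active, although the step is modest and activity remains weak. Nothing measured here explains this shift. Still open, from the compounds shown here alone, is whether the hydroxy group itself matters, which a comparison with 4-methoxyphenyl or 4-aminophenyl on this carbon could show. Also open, going by these compounds, is whether any group here can bring the number far lower.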